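This account rests on a few compounds, and the source may have more. Where it says the series, first, only, none or still open, it means among the compounds named here.

Measured so far in a functional assay on HCT-116 cells (Homo sapiens) for antiproliferative activity, read by MTT assay, with a stated time of 72 h; a higher number here means a weaker inhibitor, a lower number a stronger inhibitor:

Compound 1 `CC(C)C[C@H](NC(=O)[C@H](CC(C)C)NC(=O)N1C/C(=C\c2ccc(F)cc2)C(=O)/C(=C/c2ccc(F)cc2)C1)B1OC(C)(C)C(C)(C)O1`: 639 nM
Compound 2 `CCC[C@H](NC(=O)N1C/C(=C\c2ccc(F)cc2)C(=O)/C(=C/c2ccc(F)cc2)C1)B1OC(C)(C)C(C)(C)O1`: 785 nM

Compound 2, at 785 nM, lies within the scatter of compound 1, at 639 nM, so these two values set no order. Compound 3 `CC(C)C[C@H](NC(=O)N1C/C(=C\c2ccc(F)cc2)C(=O)/C(=C/c2ccc(F)cc2)C1)B1OC(C)(C)C(C)(C)O1` differs from compound 2 by methyl in place of hydrogen on a saturated chain carbon bound to two saturated chain carbons, with methyl in place of hydrogen on a saturated chain carbon bound to two saturated chain carbons, turning propyl to isobutyl. For the measured compounds named here, no measured step shows the effect of this change, so no shift beyond the scatter is expected in this assay. The expected move is a 1.2-fold lower number from compound 2 to compound 3 (0.08 log units; within the scatter), which is small. Compound 3 is estimated at 650 nM, with an expected range of 300 nM to 1400 nM.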

Compound 3, half-maximal inhibitory concentration: 824 nM
Compound 3: the middle estimate sits 1.3-fold (0.10 log units) below what was measured; the measured number falls inside the stated range.
By their numbers in this assay, from the lowest: compounds 1, 2 and 3 (each within the scatter of the next).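

In this assay, methyl in place of hydrogen on a saturated chain carbon bound to two saturated chain carbons, turning propyl to isobutyl, gives a 1.0-fold higher number from compound 2 to compound 3 (0.02 log units; within the scatter). At this position, then, the added methyl leaves the number within the scatter, and the two chains cannot be told apart in this assay. No evidence at hand bears on this result.

Going by these compounds, whether a longer chain, an amine or a carboxylic acid on this chain would move the number beyond the scatter remains open.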